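The source may report more compounds than this note shows. Statements on the series, on what has been measured and on what is new or still open speak of the compounds shown alone.

Among the measured compounds shown here, in an ADME assay on NHDF cells (Homo sapiens) for cytotoxicity, read by MTT assay, with a stated time of 72 h (on this read-out higher numbers stand for weaker inhibition and lower numbers for stronger inhibition), compound 1 `COc1ccc(/C=C2\CCC/C(=C\c3ccc(OC)c(OC)c3)C2=O)cc1` gives 30900 nM, the higher of the two numbers measured so far. Compound 2 `COc1ccc(/C=C2\CCC/C(=C\c3ccc(OC)c(OC)c3)C2=O)cc1OC` gives 9700 nM. Compound 3 `COc1ccc(/C=C2\CCC/C(=C\c3ccc(O)c(Cl)c3)C2=O)cc1OC` is still unmeasured, and it departs from compound 1 in one exchange: 3-chloro-4-hydroxyphenyl in place of 4-methoxyphenyl on a double-bonded chain carbon bound to a double-bonded ring carbon. Here 3-chloro-4-hydroxyphenyl replaces 4-methoxyphenyl on a double-bonded chain carbon bound to a double-bonded ring carbon. For the measured compounds named here, no measured compound carries the incoming group, so the evidence is thin. Going by the values given here, the only measured step that bears on this exchange also alters the 4-methoxyphenyl ring, placing methoxy on an aromatic carbon, and it is modest: a 3.2-fold lower number from compound 1 to compound 2 (0.50 log units; beyond the scatter). A step of similar modest size and the same downward direction is therefore expected in this assay, namely a 3.4-fold lower number from compound 1 to compound 3 (0.54 log units; beyond the scatter). The estimate for compound 3 is 9000 nM, with an expected range of 2800 nM to 29000 nM.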

Compound 3, half-maximal inhibitory concentration: 21900 nM
Beside the measured number, compound 3's estimate is 2.4-fold (0.39 log units) below it, and the stated range covers the measured number.
By their numbers in this assay, from the lowest: compound 2; then compounds 3 and 1 (each within the scatter of the next).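

On a double-bonded chain carbon bound to a double-bonded ring carbon, 3-chloro-4-hydroxyphenyl replaces 4-methoxyphenyl with a 1.4-fold lower number from compound 1 to compound 3 (0.15 log units; within the scatter) in this assay. So this exchange brings in a chlorine and a hydrogen-bond donor without moving the number past the usual scatter, whereas adding one methoxy to the 4-methoxyphenyl ring gave a 3.2-fold lower number from compound 1 to compound 2 (0.50 log units; beyond the scatter), and a larger-looking change to a ring here therefore need not produce a larger step. Nothing available explains why the number holds steady in this exchange.

The chlorine and the hydroxy enter together, so the compounds shown cannot tell whether each does little alone or whether the two offset one another. Going by these compounds, it also remains open how an amine or a carboxylic acid on the ring in this same place would read in this assay.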